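Nitrophenyl Replaces Chlorophenyl on a Shared Azetidinone-Free Core

This account rests on a few compounds, and the source may have more. Where it says the series, first, only, none or still open, it means among the compounds named here.

Measured compounds:
In a functional assay on MDA-MB-231 cells (Homo sapiens) for antiproliferative activity, read by MTT assay, with a stated time of 48 h (a lower number here means a stronger inhibitor, a higher number a weaker inhibitor), compound 1 `COC(=O)/C(=C/c1ccccc1)CN1C(=O)[C@@H](OC)[C@H]1c1ccc(Cl)cc1` gives 15600 nM.
In this assay compound 2 `COc1ccc(OC)c([C@@H]2[C@H](OC)C(=O)N2C/C(C#N)=C/c2ccccc2)c1` gives 23400 nM.
In this assay compound 3 `COC(=O)/C(=C/c1ccccc1)CN1C(=O)[C@@H](OC)[C@H]1c1cccc(C(F)(F)F)c1` gives 18200 nM.

Compound 1 carries the lowest of the three numbers, but its nearest neighbour, compound 3, sits within the scatter, and so does the furthest, compound 2; none of the three can be set apart from the others on these values.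

Compound 4 `COC(=O)/C(=C/c1ccccc1)CN1C(=O)[C@@H](OC)[C@H]1c1cccc([N+](=O)[O-])c1` has not yet been tested. It differs from compound 1 in one place: 3-nitrophenyl in place of 4-chlorophenyl on a saturated ring carbon.

Among the compounds with values here, only one measured step bears on this change, the exchange of the aryl group on the same saturated ring carbon, which gave a 1.2-fold higher number from compound 1 to compound 3 (0.07 log units; within the scatter). That step stayed within the scatter, and the change to compound 4 is of the same kind, a different substituted phenyl at the same place. The three measured compounds together show no substituent at this position pulling the number clearly in either direction.

The step from compound 1 to compound 4 is therefore expected to be a 1.1-fold higher number from compound 1 to compound 4 (0.04 log units; within the scatter), with no shift beyond the scatter. Compound 4 is expected to give 17000 nM, somewhere between 8000 nM and 36000 nM.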

Compound 4, half-maximal inhibitory concentration: 14400 nM
The estimate for compound 4 lay 1.2-fold (0.07 log units) above the measured number; the range from low to high includes it.
By their numbers in this assay, from the lowest: compounds 4, 1, 3 and 2 (each within the scatter of the next).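

In this assay, 3-nitrophenyl in place of 4-chlorophenyl on the saturated ring carbon gives a 1.1-fold lower number from compound 1 to compound 4 (0.03 log units; within the scatter), so a third substituted phenyl at this place cannot be told apart from the first two. Within the data shown here, compound 4 also adds a comparison that the earlier compounds did not allow, between two groups on the phenyl ring itself: nitro in place of trifluoromethyl on an aromatic carbon gives a 1.3-fold lower number from compound 3 to compound 4 (0.10 log units; within the scatter), and this read-out does not separate those two groups either. Nothing available here explains why these exchanges leave the number within the scatter.

As far as these compounds go, all three compounds that can be compared in this way carry a substituted phenyl at this place, so it stays open whether an amine or a carboxylic acid on that ring, or a longer chain in place of the ring, would move the number beyond the scatter. From the compounds shown here alone, compound 2 differs from the others in more than one place, so what its nitrile contributes on its own also remains open.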